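Pyridinyl for Pyrimidinyl on an Amide Nitrogen: Vero Cytotoxicity

A few compounds are considered here, and "the series" means these few. Any claim that something is new, unique, unknown or untested is made for them only; others in the source may bear on it.

Compound 1 `COc1ccc(-n2c(CCC(=O)Nc3ccc(C)cc3Cl)nc3ccccc32)cc1`: "not determined" (no result reported)
Compound 2 `COc1ccc(-n2c(SC(C)C(=O)Nc3nc(C)cc(Cl)n3)nc3ccccc32)cc1`: "not determined" (no result reported)
Compound 3 `COc1ccc(-n2c(S[C@H](C)C(=O)Nc3ccc(C)cc3Cl)nc3ccccc32)cc1`: > 75000 nM

In an ADME assay on Vero cells (Chlorocebus sabaeus) for cytotoxicity, read by MTT assay, with a stated time of 24 h (on this read-out higher numbers stand for lower toxicity in this test and lower numbers for higher toxicity in this test), compound 1 gives "not determined" (no result reported) and compound 2 gives "not determined" (no result reported), so neither carries a result. Compound 3 gives > 75000 nM, which is a limit of this assay and not a number. Compound 2 therefore stands without a number of its own; the one numeric entry among the three is a limit, and the remaining entry holds nothing. Compound 4 `COc1ccc(-n2c(SC(C)C(=O)Nc3ncc(C)cc3Cl)nc3ccccc32)cc1` differs from compound 2 by 3-chloro-5-methylpyridin-2-yl in place of 4-chloro-6-methylpyrimidin-2-yl on an amide-type nitrogen. Going by the values given here, no measured step accompanies this change, so in this assay no shift beyond the usual scatter is expected in either direction. Compound 4 is expected to give 100000 nM, between 40000 nM and 300000 nM. A limit rather than a number seems likely because of the limit of > 75000 nM in this assay, at which 1 of the 3 values shown sits.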

Compound 4, half-maximal cytotoxic concentration: 880 nM
Estimate against measurement, compound 4: 110-fold (2.06 log units) above, outside the stated range (below it).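

Going by these compounds alone, with compound 2 at "not determined" (no result reported), no step to compound 4 at 880 nM can be read. The compounds shown leave open how 3-chloro-5-methylpyridin-2-yl compares with 4-chloro-6-methylpyrimidin-2-yl on this amide-type nitrogen in this assay.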